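Dichlorophenyl analogue awaiting a cytotoxicity reading

This account rests on a few compounds, and the source may have more. Where it says the series, first, only, none or still open, it means among the compounds named here.

Compound 1 `O=[N+]([O-])c1cc(CSc2nnnn2C2CCCCC2)cc([N+](=O)[O-])c1` carries a cyclohexyl group on the shared core. In an ADME assay on HeLa cells (Homo sapiens) for cytotoxicity, read by MTT assay, with a stated time of 48 h (on this read-out lower numbers stand for stronger inhibition and higher numbers for weaker inhibition), compound 1 gives only a limit, > 30000 nM, and no number. Compound 2 `COc1ccc(-n2nnnc2SCc2cc([N+](=O)[O-])cc([N+](=O)[O-])c2)cc1`, with a 4-methoxyphenyl on the aromatic nitrogen, has no result in this assay; its entry reads "not determined" (no result reported), so nothing places it on the scale. Going by the values given here, the only value shown is the limit (the limit of > 30000 nM in this assay, at which 1 of the 2 values shown sits). Compound 3 `O=[N+]([O-])c1cc(CSc2nnnn2-c2ccc(Cl)c(Cl)c2)cc([N+](=O)[O-])c1` differs from compound 2 by 3,4-dichlorophenyl in place of 4-methoxyphenyl on an aromatic nitrogen. Among the compounds with values here, no measured step connects the two, and no step of any size in this assay can be drawn from the data; with compound 2 unmeasured, the direction of the change stays open. Given that compound 1 sits at the limit (the limit of > 30000 nM in this assay, at which 1 of the 2 values shown sits), compound 3 is expected to show weak cytotoxicity, estimated at 30000 nM with a range from 10000 nM to 100000 nM.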

Compound 3, half-maximal inhibitory concentration: > 30000 nM
Compound 3: no number, only a limit; the forecaster's own chance of this, stated with the estimate: 70%; the middle value sits exactly at the limit.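

In this assay compound 1 and compound 3 both give only a limit, so no step can be read between them: the limit of > 30000 nM in this assay, at which 2 of the 3 values shown sit. The compounds shown leave open whether 3,4-dichlorophenyl in place of cyclohexyl changes the read-out at all, and where compound 2 stands.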